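The source may report more compounds than this note shows. Statements on the series, on what has been measured and on what is new or still open speak of the compounds shown alone.

- compound 1 `C=CC(=O)N1C(=O)CC(c2ccc(Br)cc2)Sc2ccccc21` gives 59400 nM in the first measurement
- compound 2 `C=CC(=O)N1C(=O)CC(c2ccccc2C(F)(F)F)Sc2ccccc21` gives 35200 nM in the second measurement

In a functional assay on NB-4 cells (Homo sapiens) for cytotoxicity, read by CCK-8 assay, with a stated time of 24 h (a lower number here means a stronger inhibitor, a higher number a weaker inhibitor), compound 2 stands at 35200 nM and compound 1 at 59400 nM on the same scale. These two numbers lie within the usual scatter of each other, so the data cannot separate them.

The next entry is compound 3 `C=CC(=O)N1C(=O)CC(c2ccccc2)Sc2ccccc21` which derives from compound 2 with hydrogen in place of trifluoromethyl on an aromatic carbon and no other change. Within the data shown here, no measured pair differs in one place only, so this step has no direct precedent here. Among the measured compounds shown here, the only guide is the narrow spread of the two measured values, compound 1 at 59400 nM and compound 2 at 35200 nM with no separation beyond the scatter. On that basis, no change beyond the scatter is expected in this assay and any drift would most likely be a small one toward a higher number. The expected change is a 1.3-fold higher number from compound 2 to compound 3 (0.11 log units; within the scatter) and it stays within the scatter. For compound 3 the estimated value is 45000 nM with an expected range from 18000 nM to 100000 nM in this measurement.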

Compound 3, half-maximal inhibitory concentration: 35500 nM
Compound 3: middle estimate off by 1.3-fold (0.10 log units), on the high side, and the stated range covers the measured number.
By their numbers in this assay, from the lowest: compounds 2, 3 and 1 (each within the scatter of the next).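

Among these compounds, with hydrogen in place of trifluoromethyl on an aromatic carbon, ortho to a large group, this assay gives a first one-place reading at this position (a 1.0-fold higher number from compound 2 to compound 3 (0.00 log units; within the scatter)), and that step lies within the scatter. Hydrogen in place of bromo on an aromatic carbon gives a second one-place reading (a 1.7-fold lower number from compound 1 to compound 3 (0.22 log units; within the scatter)), also within the scatter. Compound 3 therefore links compound 1 and compound 2 through direct steps, and in this assay neither trifluoromethyl nor bromo can be told apart from hydrogen at its own place on the ring. No evidence is at hand that bears on what lies behind these two steps.

As far as these compounds go, it remains open whether an amine or a carboxylic acid on this aromatic ring would give a step beyond the scatter in this assay. Since all three compounds share the core of compound 3 and differ only in this ring, the shown data also leave open how this assay responds to a change elsewhere in the core.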